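Chain unsaturation in the ureido series: compound 3 next

The source may report more compounds than this note shows. Statements on the series, on what has been measured and on what is new or still open speak of the compounds shown alone.

Values so far in an ADME assay on microsomes from liver (Homo sapiens) for metabolic stability, using NADPH, with a stated time of 10 min (a lower number here means that less of the compound is left, a higher number that more of the compound is left), are:
- compound 1 `NC/C=C\CN(C[C@H]1Cc2ncccc2CN1)[C@H]1CCCc2cccnc21` with 85% 
- compound 2 `NC(=O)NCCCCN(C[C@H]1Cc2ncccc2CN1)[C@H]1CCCc2cccnc21` with 91% 

Compound 2 at 91% lies within the scatter of compound 1 at 85% in this assay, so the two numbers are not separated.

Compound 3 `NC(=O)NC/C=C/CN(C[C@H]1Cc2ncccc2CN1)[C@H]1CCCc2cccnc21` is the next to be read. Its change from compound 2 is a group of 7 heavy atoms (4 carbon, 2 nitrogen, 1 oxygen; no ring) in place of a group of 7 heavy atoms (4 carbon, 2 nitrogen, 1 oxygen; no ring), on a saturated chain carbon bound to an amine nitrogen. Both groups match in their atom counts, and they differ in the double bonds outside aromatic rings.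

Among the measured compounds shown here, only one measured step bears on this, a number 6 percentage points higher from compound 1 to compound 2 (within the scatter), with 3-ureidopropyl in place of 3-aminoprop-1-en-1-yl on a saturated chain carbon bound to an amine nitrogen. That step stays within the scatter, but it also changes the chain end. For the measured compounds named here, no measured pair isolates the double bond alone.

Compound 1, which has a double bond in its chain, gives 85% and so offers no sign of a large shift. The expected step is a number 5 percentage points lower from compound 2 to compound 3 (within the scatter), which is none beyond the scatter. For compound 3 the estimate is 86%, with 72% to 96% as the expected range.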

Compound 3, percent of the compound remaining: 93%
For compound 3 the middle estimate is 7 percentage points below the measured one; the measured number falls inside the stated range.
By their numbers in this assay, from the lowest: compounds 1, 2 and 3 (each within the scatter of the next).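

Working from this assay, the compound 2 and compound 3 pair now isolates the added double bond outside aromatic rings on a chain with matching atom counts, which no earlier pair did: the result is a number 2 percentage points higher from compound 2 to compound 3 (within the scatter). Within this ureido chain, on a saturated chain carbon bound to an amine nitrogen, the additional double bond therefore leaves the two numbers unseparated. The comparison of the two unsaturated chains gives a number 8 percentage points higher from compound 1 to compound 3 (within the scatter), so the urea-bearing chain and the shorter amine-ended chain are not separated either, and nothing measured here bears on the reason for any of these numbers.

All three compounds lie within the scatter of one another, so these data cannot show whether any chain at this position moves the read-out, and compound 1 and compound 3 also differ in chain length, chain end and double-bond geometry. A saturated 4-aminobutyl chain would complete the amine-ended pair, while a carboxylic acid at the chain end or a longer chain would test whether the same holds beyond the urea and amine ends.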